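The source may hold more compounds than are shown below. What is called first, only, known or untested is meant among the compounds shown, and "the series" means these compounds.

Compound 1, `COC(=O)CC/C(C)=C/Cc1c(OC)c(C)c2c(c1OCC#CCN1CCN(C(c3ccccc3)c3ccccc3)CC1)C(=O)OC2`, is the point of departure. In a functional assay on A549 cells (Homo sapiens) for inhibition, read by sulforhodamine B assay (a higher number here means a weaker inhibitor, a lower number a stronger inhibitor), compound 1 gives 32700 nM, the lowest of the two numbers in hand, though its nearest neighbour lies within the usual scatter. Compound 2, `COC(=O)CC/C(C)=C/Cc1c(OC)c(C)c2c(c1OCC#CCN1CCN(c3ccc(C#N)cc3)CC1)C(=O)OC2`, reaches only the limit of the assay, > 50000 nM. Among the compounds with values here, compound 3, `COC(=O)CC/C(C)=C/Cc1c(OC)c(C)c2c(c1OCC#CCN1CCN(c3ccccc3F)CC1)C(=O)OC2`, gives 45300 nM in this assay; the move an at least 1.1-fold lower number from compound 2 to compound 3 (0.04 log units; that floor lies within the scatter) is the one measured step, and it lies within the scatter, so little is learned from it (the limit of > 50000 nM in this assay, at which 1 of the 3 values shown sits). Compound 4, `COC(=O)CC/C(C)=C/Cc1c(OC)c(C)c2c(c1OCC#CCN1CCN(C(c3ccccc3)c3ccc(Cl)cc3)CC1)C(=O)OC2`, differs from compound 1 by chloro in place of hydrogen on an aromatic carbon. Within the data shown here, no measured step touches this part of the molecule, and the one step that exists concerns a different aryl group on the amine nitrogen in the ring and is itself small. Compound 4 is therefore expected to show no change beyond the scatter, a 1.1-fold lower number from compound 1 to compound 4 (0.04 log units; within the scatter), and its value in this assay is estimated at 30000 nM, with a range from 12000 nM to 60000 nM.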

Compound 4, half-maximal inhibitory concentration: 29100 nM
Beside the measured number, compound 4's estimate is 1.0-fold (0.01 log units) above it; low and high end bracket the measured number.
By their numbers in this assay, from the lowest: compounds 4, 1 and 3 (each within the scatter of the next). At a limit, above all of these: compound 2.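

Within the data shown here, the first measured reading at this position is a 1.1-fold lower number from compound 1 to compound 4 (0.05 log units; within the scatter), so in this assay the change from phenyl to 4-chlorophenyl gives no difference that can be told from the scatter. Among these compounds, the earlier step concerned a different aryl group on the amine nitrogen in the ring, so it said nothing about this ring, and this result is the first direct reading for it. Compound 2 stands at a limit and not at a number, and it adds no reading for this position: the limit of > 50000 nM in this assay, at which 1 of the 4 values shown sits.

Going by these compounds, it remains open whether a group other than chloro at this place, such as methoxy, an amine or a carboxylic acid, would move the number beyond the scatter. Also open, on these data alone, is what chloro or fluoro would do on the second phenyl ring of compound 4.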